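Moving the methoxy group to the ortho position of the phenyl

A few compounds are considered here, and "the series" means these few. Any claim that something is new, unique, unknown or untested is made for them only; others in the source may bear on it.

Of the compounds shown here, three sharing one core have been tested so far, all in a functional assay on HT-29 cells (Homo sapiens) for antiproliferative activity, read by sulforhodamine B assay, with a stated time of 48 h; a lower number here means a stronger inhibitor of growth, a higher number a weaker inhibitor of growth. Compound 1 `Cc1ccc(-c2cc(N3CCC(CNS(N)(=O)=O)CC3)ncn2)cc1` gives 33900 nM, the highest of the three numbers. Compound 2 `CCCCc1ccc(-c2cc(N3CCC(CNS(N)(=O)=O)CC3)ncn2)cc1` gives 15200 nM, and compound 3 `COC(=O)c1ccc(-c2cc(N3CCC(CNS(N)(=O)=O)CC3)ncn2)cc1` gives 22900 nM. The step of a 2.2-fold lower number from compound 1 to compound 2 (0.35 log units; beyond the scatter) is the only one that clearly exceeds the scatter; the step of a 1.5-fold lower number from compound 1 to compound 3 (0.17 log units; within the scatter) and the step of a 1.5-fold higher number from compound 2 to compound 3 (0.18 log units; within the scatter) do not.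

Compound 4 `COc1ccccc1-c1cc(N2CCC(CNS(N)(=O)=O)CC2)ncn1` differs from compound 1 as follows: 2-methoxyphenyl in place of 4-methylphenyl on an aromatic carbon. The measured steps all swap one group for another at the same position of the phenyl ring, so none of them bears directly on a group in a different position. Since even the largest measured step is modest and the others are within the scatter, no step beyond the scatter is expected in this assay . This expectation corresponds to a 1.2-fold lower number from compound 1 to compound 4 (0.08 log units; within the scatter). Compound 4 is therefore expected to give about 28000 nM, with a range from 12000 nM to 65000 nM.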

Compound 4, concentration for 50% growth inhibition: > 100000 nM
Compound 4: no number, only a limit; the forecaster's own chance of this, stated with the estimate: 10%; middle value at least 3.5-fold (0.55 log units) away from the limit.
By their numbers in this assay, from the lowest: compounds 2, 3 and 1 (each within the scatter of the next, the first and the last beyond it). At a limit, above all of these: compound 4.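

In this assay compound 4 gives only a limit, not a number: the limit of > 100000 nM in this assay, at which 1 of the 4 values shown sits. Among the compounds shown here, replacing 4-methylphenyl with 2-methoxyphenyl gives an at least 2.9-fold higher number from compound 1 to compound 4 (0.46 log units; beyond the scatter), which runs in the opposite direction to the one earlier step beyond the scatter, a 2.2-fold lower number from compound 1 to compound 2 (0.35 log units; beyond the scatter). For the compounds shown here, the aromatic group on this carbon of the shared core can therefore weaken growth inhibition clearly, something the earlier compounds did not show.

Compound 4 changes two things at once, swapping a methyl group for a methoxy group and moving the group to a different place on the phenyl, so the compounds shown cannot separate these two changes. Going by these compounds, a 4-methoxyphenyl or a 2-methylphenyl group would tell them apart, and how an amine or a carboxylic acid on the phenyl would behave also stays open.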